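Ethoxyphenyl to nitrophenyl on the triazole nitrogen

The compounds below may be only part of what the source reports. "The series", "measured", "known", "first", "only" and "open" are said of these compounds alone.

Going by the values given here, compound 2 `CCOc1ccccc1-n1nncc1CN1C(=O)C2(C(C#N)=C(N)Oc3c(N)cc4nc5ccccc5nc4c32)c2ccccc21` is the only member of the series with a number in a functional assay on HepG2 cells (Homo sapiens) for antiproliferative activity, read by MTT assay, with a stated time of 48 h (a lower number here means a stronger inhibitor, a higher number a weaker inhibitor), where compound 2 gives 30500 nM. Compound 1 `CCOc1ccc(-n2nncc2CN2C(=O)C3(C(C#N)=C(N)Oc4c(N)cc5nc6ccccc6nc5c43)c3ccccc32)cc1` reaches only a limit of this assay, > 50000 nM; this is the limit of > 50000 nM in this assay, at which 1 of the 2 values shown sits. Among the compounds with values here, the one measured step, an at least 1.6-fold lower number from compound 1 to compound 2 (0.21 log units; that floor lies within the scatter), moves the 2-ethoxyphenyl in place of 4-ethoxyphenyl on an aromatic nitrogen, and its floor lies within the scatter.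

Compound 3 `N#CC1=C(N)Oc2c(N)cc3nc4ccccc4nc3c2C12C(=O)N(Cc1cnnn1-c1ccc([N+](=O)[O-])cc1)c1ccccc12` carries the change (4-nitrophenyl in place of 2-ethoxyphenyl on an aromatic nitrogen), again a substituent swap on the aromatic nitrogen of the five-membered aromatic ring with 3 nitrogen. Within the data shown here, the only step that bears on it is the one from compound 1 to compound 2, a swap at the same place that gave at best a small change; no measured step shows a nitro group anywhere. The expectation is therefore no movement beyond the scatter in this assay, with a real chance that compound 3 again returns only a limit. For compound 3 the estimate in this assay is 30000 nM, between 10000 nM and 60000 nM, an expected step of a 1.0-fold lower number from compound 2 to compound 3 (0.01 log units; within the scatter).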

Compound 3, half-maximal inhibitory concentration: > 50000 nM
Compound 3: only a limit was reported; the forecaster's own chance of this, stated with the estimate: 40%; middle value at least 1.6-fold (0.22 log units) away from the limit.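

Putting 4-nitrophenyl in place of 2-ethoxyphenyl on the aromatic nitrogen of the five-membered ring gives an at least 1.6-fold higher number from compound 2 to compound 3 (0.21 log units; that floor lies within the scatter), so this change has no effect shown beyond the scatter in this assay. Compound 3 gives > 50000 nM, which is a limit and not a number, and the step from compound 1 to compound 3 cannot be read. Compound 1 with 4-ethoxyphenyl and compound 3 with 4-nitrophenyl now sit at the same limit, while compound 2 with 2-ethoxyphenyl is the only one with a number: the limit of > 50000 nM in this assay, at which 2 of the 3 values shown sit.

The compounds shown do not separate the place of the substituent on the phenyl ring from its kind, and a nitro group at the place of the ethoxy group of compound 2 would bear directly on that. Also open, from the compounds shown here alone, is whether an amine or a carboxylic acid on this phenyl ring, or a chain longer than ethoxy, would give a number clearly away from the limit in this assay.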